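The source may report more compounds than this note shows. Statements on the series, on what has been measured and on what is new or still open speak of the compounds shown alone.

Measured compounds:
- compound 1, `COc1cc(C)cc(-c2nn(CC#N)cc2-c2ccc(-c3cccc(C(C)=O)c3)nc2)c1`: > 100000 nM in a functional assay on SW-620 cells (Homo sapiens) for inhibition, read by sulforhodamine B assay, with a stated time of 48 h; on this read-out lower numbers stand for higher toxicity in this test and higher numbers for lower toxicity in this test
- compound 2, `Cc1cc(O)cc(-c2nn(CC#N)cc2-c2ccnc(-c3ccc(Oc4ccccc4)cc3)c2)c1`: 9630 nM

In this assay compound 1 gives only a limit, (the limit of > 100000 nM in this assay, at which 1 of the 2 values shown sits). Among the compounds with values here, compound 2 therefore stands as the single actual number in the set. Compound 3, `Cc1cc(O)cc(-c2nn(CC#N)cc2-c2ccnc(-c3ccc(N(C)C)cc3)c2)c1`, is not yet measured; it differs from compound 2 in one place: dimethylamino in place of phenoxy on an aromatic carbon. Within the data shown here, no measured step in the set bears on this change, so the expectation for a 1.6-fold higher number from compound 2 to compound 3 (0.19 log units; within the scatter) is a step of modest size toward lower toxicity, possibly within the scatter. Compound 3 is estimated at 15000 nM, range 4000 nM to 60000 nM.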

Compound 3, concentration lethal to 50% of the cells: > 100000 nM
Compound 3: no number, only a limit; the forecaster's own chance of this, stated with the estimate: 15%; at least 6.6-fold (0.82 log units) between middle value and limit.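

In this assay, within the data shown here, dimethylamino in place of phenoxy on this aromatic carbon, para to a large group, gives an at least 10-fold higher number from compound 2 to compound 3 (1.01 log units; beyond the scatter), the first readable step, and it lies beyond the scatter. The value for compound 3 is a limit, so the step has a minimum size only: the limit of > 100000 nM in this assay, at which 2 of the 3 values shown sit. Among these compounds, compound 2 remains the only compound here with an actual number.

Going by these compounds, whether the ring or the ether oxygen of phenoxy matters stays open. A methoxy or a phenyl group on this carbon would separate the two.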